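The source may hold more compounds than are shown below. What is called first, only, known or untested is meant among the compounds shown, and "the series" means these compounds.

For the measured compounds named here, in an ADME assay on microsomes from liver (Mus musculus) for metabolic stability, read by LC-MS, with a stated time of 30 min, tested at 0.1 uM (a higher number here means that more of the compound is left, a lower number that less of the compound is left), compound 1 `Fc1cnc(Nc2cc3[nH]c(-c4cccc(C(F)(F)F)c4)nc3cn2)c(F)c1` gives 49% and compound 2 `FC(F)(F)c1ccc(Nc2cc3[nH]c(-c4cccc(C(F)(F)F)c4)nc3cn2)nc1` gives 91%, the higher of the two numbers so far. Compound 3 `FC(F)(F)c1ccc(Nc2cc3[nH]c(C4CCOCC4)nc3cn2)nc1` differs from compound 2 as follows: oxan-4-yl in place of 3-(trifluoromethyl)phenyl on an aromatic carbon. Going by the values given here, the only measured step, a number 42 percentage points higher from compound 1 to compound 2 (beyond the scatter), was large, but it changed the group on a nitrogen on an aromatic ring, so it offers little guidance here. Compound 2 at 91% has little room to rise. A modest fall is therefore expected, an estimated a number 13 percentage points lower from compound 2 to compound 3 (beyond the scatter). The expected value for compound 3 is 78%, within a range of 50% to 96%.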

Compound 3, percent of the compound remaining: 55%
Compound 3: the middle estimate sits 23 percentage points above what was measured, within the range that was stated.
By their numbers in this assay, from the lowest: compounds 1 and 3 (each within the scatter of the next); then compound 2.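

The earlier pair changed only the group on a nitrogen on an aromatic ring. This result shows that the aromatic carbon of the five-membered ring also matters in this assay: oxan-4-yl in place of 3-(trifluoromethyl)phenyl gives a number 36 percentage points lower from compound 2 to compound 3 (beyond the scatter). Nothing available here explains this fall.

The compounds shown leave open whether the change in this assay follows from the ring oxygen or from giving up the aromatic ring. A cyclohexyl or an unsubstituted phenyl group at this place would help separate the two.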